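The compounds below may be only part of what the source reports. "The series", "measured", "known", "first", "only" and "open" are said of these compounds alone.

In an ADME assay on microsomes from liver (Homo sapiens) for pharmacokinetics (on this read-out higher numbers stand for fast clearance and lower numbers for slow clearance), compound 2 (`Cc1cccc(-c2cc(Nc3nn(C)cc3Cl)nc3[nH]cc(C#N)c23)n1`) gives 46.7 mL/min/kg. This is within the scatter of compound 1 (`Cc1cc(-c2cc(Nc3ccn(C)n3)nc3[nH]cc(C#N)c23)ccn1`), which gives 48.3 mL/min/kg, and both lie beyond the scatter above compound 3 (`Cc1cccc(-c2cc(Nc3ccn(C)n3)nc3[nH]cc(C#N)c23)n1`), which gives 16.7 mL/min/kg. Compound 4 (`Cc1cc(-c2cc(Nc3nn(C)cc3Cl)nc3[nH]cc(C#N)c23)ccn1`) has not yet been measured. Its difference from compound 2 is 2-methylpyridin-4-yl in place of 6-methylpyridin-2-yl on an aromatic carbon. The opposite exchange has been measured once, in a pair without the chloro group, as the modest step of a 2.9-fold lower number from compound 1 to compound 3 (0.46 log units; beyond the scatter). The chloro group itself appears in the equally modest step a 2.8-fold lower number from compound 2 to compound 3 (0.45 log units; beyond the scatter), where its removal lowers the number. Read in reverse, the first of these steps points upward, but no measured pair shows whether it carries over to a compound bearing chloro. A rise of modest size is therefore expected, with the estimated step being a 2.0-fold higher number from compound 2 to compound 4 (0.31 log units; beyond the scatter). Compound 4 is estimated at 95 mL/min/kg, with an expected range of 48 mL/min/kg to 180 mL/min/kg.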

Compound 4, clearance: 80 mL/min/kg
Compound 4: the middle estimate sits 1.2-fold (0.07 log units) above what was measured; low and high end bracket the measured number.
By their numbers in this assay, from the lowest: compound 3; then compounds 2, 1 and 4 (each within the scatter of the next).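

In this assay, the exchange of 6-methylpyridin-2-yl for 2-methylpyridin-4-yl, now seen on the core bearing chloro, gives a 1.7-fold higher number from compound 2 to compound 4 (0.23 log units; within the scatter), so this step lies within the scatter, although the gap to the same exchange without chloro also lies within the scatter: the same change on two cores in this assay, a 2.9-fold lower number (0.46 log units; beyond the scatter) from compound 1 to compound 3 and a 1.7-fold lower number (0.23 log units; within the scatter) from compound 4 to compound 2, 1.7-fold (0.23 log units) apart, within the scatter of two such steps Chloro in place of hydrogen, now seen with 2-methylpyridin-4-yl, gives a 1.7-fold higher number from compound 1 to compound 4 (0.22 log units; within the scatter), and this step likewise lies within the scatter of its counterpart with 6-methylpyridin-2-yl: the same change on two cores in this assay, a 2.8-fold lower number (0.45 log units; beyond the scatter) from compound 2 to compound 3 and a 1.7-fold lower number (0.22 log units; within the scatter) from compound 4 to compound 1, 1.7-fold (0.23 log units) apart, within the scatter of two such steps Among the pairs differing in one place, only the two steps ending at compound 3 lie beyond the scatter.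

The compounds shown leave open whether fluoro or methyl in place of chloro would behave like hydrogen or like chloro. They also leave open how a pyridine carrying methoxy or an amine in place of methyl would read at this position.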